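The source may hold more compounds than are shown below. What is called first, only, known or untested is meant among the compounds shown, and "the series" means these compounds.

Working notes on the series.

Three compounds have numbers in a functional assay for antagonist activity at melanin-concentrating hormone receptor 1 (Homo sapiens); a higher number here means a weaker inhibitor, a lower number a stronger inhibitor. Compound 1 `NCc1cnc([C@]23CC[C@@H](N(CCN4CCCC4)C(=O)Nc4ccc(F)c(C(F)(F)F)c4)CC2C3)s1` gives 431 nM. Compound 2 `C[C@@H]1CN(CCCN(C(=O)Nc2ccc(F)c(C(F)(F)F)c2)[C@@H]2CC[C@]3(c4cnc(CN)s4)CC23)[C@@H](C)CN1` gives 19 nM. Compound 3 `C[C@@H]1CN(CCCN(C(=O)Nc2cc(Cl)nc(Cl)c2)[C@@H]2CC[C@]3(c4cnc(CN)s4)CC23)[C@@H](C)CN1` gives 13.1 nM, the lowest of the three numbers; its nearest neighbour is compound 2, within the scatter, and its furthest is compound 1, beyond it. Within the data shown here, the one single-point step measured so far, a 1.5-fold lower number from compound 2 to compound 3 (0.16 log units; within the scatter), exchanges 2,6-dichloropyridin-4-yl for 4-fluoro-3-(trifluoromethyl)phenyl on an amide-type nitrogen and stays within the scatter.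

Compound 4 `C[C@@H]1CN[C@@H](C)CN1CCCN(C(=O)Nc1cc(Cl)nc(Cl)c1)[C@H]1CC[C@]2(c3cnc(CN)s3)C[C@H]12` keeps every atom and bond of compound 3; the change is the two compounds have the same atoms and bonds; at least one stereo element is drawn with a configuration in one of them and without one in the other: 4 of 5 stereo elements differ; a stereocentre at a saturated ring carbon is drawn S in compound 3 and R in compound 4; a stereocentre at a saturated ring carbon is drawn R in compound 3 and S in compound 4; a stereocentre at a saturated ring carbon is drawn R in compound 3 and S in compound 4; a stereocentre at a saturated ring carbon is drawn without a configuration in compound 3 and S in compound 4. Among the measured compounds shown here, no measured step in this assay touches a stereo element, so there is nothing among the three measured compounds that bears directly on this change, and the size and direction of the step from compound 3 to compound 4 cannot be read from them. Stereo changes of this extent at the saturated core are taken to carry a real risk of a weaker number, so the expected step is a 9.2-fold higher number from compound 3 to compound 4 (0.96 log units; beyond the scatter), toward a higher number, with a wide range. For compound 4 the estimate is 120 nM, expected between 15 nM and 1000 nM.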

Compound 4, inhibition constant: 4 nM
Estimate against measurement, compound 4: 30-fold (1.48 log units) above, outside the stated range (below it).
By their numbers in this assay, from the lowest: compound 4; then compounds 3 and 2 (each within the scatter of the next); then compound 1.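

Among these compounds, this is the first measured step in this assay that touches stereo elements, and it runs toward a lower number: a 3.3-fold lower number from compound 3 to compound 4 (0.52 log units; beyond the scatter). With the 2,6-dichloropyridin-4-yl group held constant, compound 4 shows that redrawing four of the five stereo elements, all at saturated ring carbons, need not cost activity, and the resulting number is the lowest of the four in the series. The step still cannot be assigned to a true inversion at every one of those carbons, and its size has to be read with that caution: the fact that one of compounds 3 and 4 is drawn with a defined configuration and the other without, at the place where they differ.

Which of the four stereo elements carries the step remains open, as does whether the same configuration would give a similar step with the 4-fluoro-3-(trifluoromethyl)phenyl group of compound 2 in place of the 2,6-dichloropyridin-4-yl group. Also open, as far as these compounds go, is how this stereo arrangement would respond to a longer chain on the amide-type nitrogen or to an added carboxylic acid.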